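Working notes: ethyl on the chain of compound 2

This account rests on a few compounds, and the source may have more. Where it says the series, first, only, none or still open, it means among the compounds named here.

Measured in a functional assay on the whole organism for inhibition, with Cavia porcellus as the target; a lower number here means that less compound is needed, a higher number that more compound is needed for the effect:
- compound 1 `COc1ccccc1OCC1SCCN1C(=O)CN` gives 57 mg/kg
- compound 2 `COc1ccccc1OCC1SCCN1C(=O)CC(C)=O` gives 30 mg/kg

Compound 2, at 30 mg/kg, has a single measured neighbour, and the two values lie within the scatter of each other. Among the compounds with values here, the only measured step is a 1.9-fold lower number from compound 1 to compound 2 (0.28 log units; within the scatter), with acetyl in place of amino on a saturated chain carbon bound to a carbonyl carbon. Next in the series is compound 3 `CCCC(=O)CC(=O)N1CCSC1COc1ccccc1OC`, and its change from compound 2 is ethyl in place of hydrogen on a saturated chain carbon bound to a carbonyl carbon. Within the data shown here, no measured step involves ethyl, so the one available step bears on this change only indirectly. With that single exchange on the chain, a 1.9-fold lower number from compound 1 to compound 2 (0.28 log units; within the scatter), no shift beyond the scatter is expected in this assay, in either direction. The step expected is no change at the digits printed from compound 2 to compound 3 (within the scatter). The estimated value for compound 3 is 30 mg/kg, with an expected range from 13 mg/kg to 70 mg/kg.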

Compound 3, dose for half-maximal effect: 42 mg/kg
Beside the measured number, compound 3's estimate is 1.4-fold (0.15 log units) below it; measured number inside the range.
By their numbers in this assay, from the lowest: compounds 2, 3 and 1 (each within the scatter of the next).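

In this assay, ethyl in place of hydrogen on a saturated chain carbon bound to a carbonyl carbon gives a 1.4-fold higher number from compound 2 to compound 3 (0.15 log units; within the scatter), so this place accepts the ethyl group with no shift beyond the scatter. Propylcarbonyl in place of amino gives a 1.4-fold lower number from compound 1 to compound 3 (0.13 log units; within the scatter), so propylcarbonyl, like acetyl, stays within the scatter of amino at this place. No measured evidence bearing on these results is available.

With amino, acetyl and propylcarbonyl all within the scatter of one another, no group shown here is separated from the others in this assay. From the compounds shown here alone, it remains open whether a longer chain such as hexyl, a phenyl ring or a carboxylic acid at this place would give a step beyond the scatter, and in which direction.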